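Chlorophenyl placement on the triazole arm of compound 1

The compounds below may be only part of what the source reports. "The series", "measured", "known", "first", "only" and "open" are said of these compounds alone.

Compound 1 `COc1ccc([C@@H]2CC(=O)c3c(O)cc(OCc4cn(Cc5cccc(Cl)c5)nn4)cc3O2)cc1O` carries a 3-chlorobenzyl group on the triazole. In a functional assay on RAW264.7 cells (Mus musculus) for inhibition, read by Griess assay, with stated times of 2 h and 24 h (on this read-out higher numbers stand for weaker inhibition and lower numbers for stronger inhibition), compound 1 gives 18200 nM, the higher of the two numbers recorded so far. Compound 2 `CCCn1cc(COc2cc(O)c3c(c2)O[C@H](c2ccc(OC)c(O)c2)C/C3=N\O)nn1`, built on a different core and with a propyl group on the triazole, gives 2340 nM in this assay; the gap between compound 1 and compound 2 lies beyond the scatter, but the two differ in several places at once, so no single change can be read from the pair.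

Compound 3 `COc1ccc([C@@H]2CC(=O)c3c(O)cc(OCc4cn(Cc5ccccc5Cl)nn4)cc3O2)cc1O` differs from compound 1 in one place: 2-chlorophenyl in place of 3-chlorophenyl on a saturated chain carbon bound to an aromatic nitrogen. Nothing is added or removed. For the measured compounds named here, no measured pair in this set shows what such a shift does. The expected outcome is therefore a step of a 1.0-fold lower number from compound 1 to compound 3 (0.00 log units; within the scatter), that is none beyond the scatter, in either direction. Compound 3 is expected to give 18000 nM in this assay, within a range of 6000 nM to 50000 nM.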

Compound 3, half-maximal inhibitory concentration: 6140 nM
For compound 3 the middle estimate is 2.9-fold (0.47 log units) above the measured one; low and high end bracket the measured number.
By their numbers in this assay, from the lowest: compound 2; then compound 3; then compound 1.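

Exchanging 3-chlorobenzyl for 2-chlorobenzyl on the shared core gives, in this assay, a 3.0-fold lower number from compound 1 to compound 3 (0.47 log units; beyond the scatter). The two groups have the same atoms and the same counts, so the placement of the chlorine alone is enough to move the number beyond the scatter at this position, which compound 1 and compound 2, differing in several places at once, could not show. Nothing at hand gives a reason for this step.

Whether an unsubstituted benzyl group, or a bromine or methoxy group in place of the chlorine on the 2-chlorobenzyl, would move the number further in the same direction stays open, as only two placements of the chlorine are shown. Also open, from the compounds shown here alone, is whether the same step would hold on the core of compound 2.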